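The compounds below may be only part of what the source reports. "The series", "measured", "known", "first", "only" and "open" are said of these compounds alone.

Going by the values given here, compound 2 `N#Cc1cc(F)cc(C(=O)Nc2cccc(Cl)c2)c1` is the only compound of the three for which an in vitro functional assay on HEK293-A cells for antagonist activity at metabotropic glutamate receptor 5 (Rattus norvegicus), read by calcium flux (on this read-out higher numbers stand for weaker inhibition and lower numbers for stronger inhibition), returns a number: in this assay compound 2 gives 45 nM. Compound 1 `N#Cc1cc(F)cc(C(=O)Nc2ccc(F)cc2)c1` stops at a limit, since in this assay compound 1 gives > 10000 nM, a limit and not a number. Compound 3 `Cc1ccc(NC(=O)c2cc(F)cc(C#N)c2)cc1` also stops at a limit, as in this assay compound 3 gives > 30000 nM. Among the compounds with values here, the only single change measured, from compound 1 to compound 3, is a step that the two limits leave unreadable from compound 1 to compound 3, so it offers no size to lean on; the two limits are the limit of > 10000 nM in this assay, at which 1 of the 3 values shown sits, and (the limit of > 30000 nM in this assay, at which 1 of the 3 values shown sits).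

Compound 4 `CC(C)(C)c1cccc(NC(=O)c2cc(F)cc(C#N)c2)c1` differs from compound 2 by tert-butyl in place of chloro on an aromatic carbon. Within the data shown here, no measured step swaps chloro for tert-butyl, so the expectation rests on compound 2 alone, where a group meta to a large group already gives 45 nM. In this assay compound 4 is therefore expected to show a step of a 3.3-fold higher number from compound 2 to compound 4 (0.52 log units; beyond the scatter), a modest weakening that may still lie within the scatter. The estimate for compound 4 in this assay is 150 nM, between 25 nM and 1000 nM.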

Compound 4, half-maximal inhibitory concentration: > 30000 nM
Compound 4: only a limit was reported; the forecaster's own chance of this, stated with the estimate: 10%; middle value at least 200-fold (2.30 log units) away from the limit.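

In this assay, the place meta to a large group proves far from indifferent to what sits there: tert-butyl in place of chloro gives an at least 660-fold higher number from compound 2 to compound 4 (2.82 log units; beyond the scatter). Going by these compounds alone, this is the first step that can be given a size, as it starts from a measured number, whereas the two limits of the earlier pair left their step unreadable. Compound 4 stops at a limit and not a number, so the step gives only a minimum for the change: the limit of > 30000 nM in this assay, at which 2 of the 4 values shown sit.

The compounds shown leave open how bromo, ethyl or methoxy would read at this same place, and so whether the read-out worsens gradually or abruptly on going from chloro to tert-butyl. They also leave open whether any group at this place improves on chloro.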